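The source may hold more compounds than are shown below. What is called first, only, known or untested is meant among the compounds shown, and "the series" means these compounds.

Working notes on the series. Going by the values given here, in a functional assay on CV-1 cells for agonist activity at Bile acid receptor (Homo sapiens), read by a luciferase reporter (on this read-out lower numbers stand for an effect already at smaller amounts and higher numbers for an effect only at larger amounts of compound), compound 3 `CC(C)Oc1cc(C(=O)O)nc2ccc(-c3ccc(OCc4c(-c5c(Cl)cccc5Cl)noc4C(C)C)cc3)cc12` gives 14 nM and stands lowest of the three numbers measured so far, though only within the scatter of compound 2 `COc1cc(C(=O)O)nc2ccc(-c3ccc(OCc4c(-c5c(Cl)cccc5Cl)noc4C(C)C)cc3)cc12`, which gives 17 nM; compound 1 `CC(C)c1onc(-c2c(Cl)cccc2Cl)c1COc1ccc(-c2ccc3nc(C(=O)O)cc(O)c3c2)cc1` gives 10000 nM. The steps from the unsubstituted oxygen are large: a 590-fold lower number from compound 1 to compound 2 (2.77 log units; beyond the scatter) and a 710-fold lower number from compound 1 to compound 3 (2.85 log units; beyond the scatter), whereas a 1.2-fold lower number from compound 2 to compound 3 (0.08 log units; within the scatter). Compound 4 `CCCOc1cc(C(=O)O)nc2ccc(-c3ccc(OCc4c(-c5c(Cl)cccc5Cl)noc4C(C)C)cc3)cc12` differs from compound 3 by propyl in place of isopropyl on an oxygen on an aromatic ring. Among the compounds with values here, the only step that bears on it is the exchange of one small alkyl for another on this oxygen, and that step from compound 2 to compound 3 lay within the scatter, so no step beyond the scatter is expected in this assay for no change at the digits printed from compound 3 to compound 4 (within the scatter). Compound 4 is therefore expected at 14 nM, within 6 nM to 35 nM.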

Compound 4, half-maximal effective concentration: 22 nM
For compound 4 the middle estimate is 1.6-fold (0.20 log units) below the measured one; low and high end bracket the measured number.
By their numbers in this assay, from the lowest: compounds 3, 2 and 4 (each within the scatter of the next); then compound 1.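

In this assay, branched isopropyl and straight propyl on this oxygen are not told apart, with a 1.6-fold higher number from compound 3 to compound 4 (0.20 log units; within the scatter). Lengthening the chain from methyl to propyl also leaves the number within the scatter, with a 1.3-fold higher number from compound 2 to compound 4 (0.11 log units; within the scatter). The large step away from hydrogen on this oxygen therefore holds for a straight chain as well, with a 450-fold lower number from compound 1 to compound 4 (2.66 log units; beyond the scatter).

No measurement at hand accounts for these results. Going by these compounds, whether a longer chain, or an amine or carboxylic acid at the end of the propyl, would keep the number at this level remains open.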